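The source may report more compounds than this note shows. Statements on the series, on what has been measured and on what is new or still open speak of the compounds shown alone.

Three members of the series have been run in a functional assay on CHO cells for inhibition of metabotropic glutamate receptor 5 (Rattus norvegicus), read by FLIPR and calcium flux; a lower number here means a stronger inhibitor, a higher number a weaker inhibitor. Compound 1 `Cc1ccc2ccc(-c3cc(Cl)cc(C#N)c3)cc2n1` gives 1.4 nM. Compound 2 `Cc1ccc2ccc(-c3cc(C#N)cc(OC(F)(F)F)c3)cc2n1` gives 75 nM in this assay, the step being a 54-fold higher number from compound 1 to compound 2 (1.73 log units; beyond the scatter). Compound 3 `COCCOc1cc(C#N)cc(-c2ccc3ccc(C)nc3c2)c1` gives 82 nM in this assay, the step being a 59-fold higher number from compound 1 to compound 3 (1.77 log units; beyond the scatter). Compound 3 thus holds the highest number of the three; against compound 2 the step is a 1.1-fold higher number from compound 2 to compound 3 (0.04 log units; within the scatter), so the two cannot be separated, while the gap to compound 1 is large.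

Compound 4 `CCS(=O)(=O)c1cc(C#N)cc(-c2ccc3ccc(C)nc3c2)c1` differs from compound 3 by ethylsulfonyl in place of 2-methoxyethoxy on an aromatic carbon. Two kinds of step bear on this. Exchanging one substituent for another at this aromatic carbon gave a 1.1-fold higher number from compound 2 to compound 3 (0.04 log units; within the scatter), nothing beyond the scatter. Leaving chloro for either larger group gave a 54-fold higher number from compound 1 to compound 2 (1.73 log units; beyond the scatter) and a 59-fold higher number from compound 1 to compound 3 (1.77 log units; beyond the scatter). Among the compounds with values here, no ethylsulfonyl analogue has been measured, so its direction is open. Compound 4 is expected to stay near compound 3, with an estimated step of a 1.2-fold higher number from compound 3 to compound 4 (0.09 log units; within the scatter). For compound 4 the estimate in this assay is 100 nM, within 30 nM to 400 nM.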

Compound 4, half-maximal inhibitory concentration: 1090 nM
The estimate for compound 4 lay 11-fold (1.04 log units) below the measured number; measured number above the stated range.
By their numbers in this assay, from the lowest: compound 1; then compounds 2 and 3 (each within the scatter of the next); then compound 4.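

Larger groups are not interchangeable at this aromatic carbon: trifluoromethoxy and 2-methoxyethoxy could not be separated, yet ethylsulfonyl, which matches 2-methoxyethoxy at 5 heavy atoms and 2 hydrogen-bond acceptors, gives a 13-fold higher number from compound 3 to compound 4 (1.12 log units; beyond the scatter) and a 15-fold higher number from compound 2 to compound 4 (1.16 log units; beyond the scatter) in this series. Against chloro the change reaches a 780-fold higher number from compound 1 to compound 4 (2.89 log units; beyond the scatter) and is the largest step in the set, so the level shared by compounds 2 and 3 is not a floor for this position. Nothing measured on these compounds accounts for the separation of ethylsulfonyl from the other two larger groups.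

As far as these compounds go, whether a fluoro or methyl group would match chloro remains open. So does whether a methylsulfonyl or a sulfonamide would follow ethylsulfonyl or return to the level of compounds 2 and 3.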